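Pyrazole series: hydroxy versus methoxy at the phenol oxygen

The source may hold more compounds than are shown below. What is called first, only, known or untested is meant among the compounds shown, and "the series" means these compounds.

Measured so far in a functional assay on Hs-578T cells (Homo sapiens) for cytotoxicity, read by sulforhodamine B assay, with a stated time of 48 h, tested at 0.01 uM; on this read-out lower numbers stand for a stronger effect and higher numbers for a weaker effect at the one concentration tested:
- compound 1, `Cc1cc(O)cc(-c2nn(CC#N)cc2-c2ccnc(-c3ccc(Oc4ccccc4)cc3)c2)c1`, gives 91%
- compound 2, `COc1cc(C)cc(-c2nn(CC#N)cc2-c2ccnc(-c3ccc(N(C)C)cc3)c2)c1`, gives 100%

Compound 2 stands highest of the two numbers; compound 1 sits nine points lower, within the scatter, so the two are not distinguished. Compound 3, `Cc1cc(O)cc(-c2nn(CC#N)cc2-c2ccnc(-c3ccc(N(C)C)cc3)c2)c1`, differs from compound 2 by hydrogen in place of methyl on an oxygen on an aromatic ring. Compound 1, which carries the same hydroxy group, gives 91% in this assay, so no step beyond the scatter is expected here. For compound 3 the expected change is a number 4 percentage points lower from compound 2 to compound 3 (within the scatter), leaving this assay near the top of the scale. Compound 3 is estimated at 96%, range 84% to 106%.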

Compound 3, a percentage reported as activity, at one concentration (the size of the read-out at that concentration, not a potency): 95%
Compound 3: middle estimate off by 1 percentage points, on the high side; low and high end bracket the measured number.
By their numbers in this assay, from the lowest: compounds 1, 3 and 2 (each within the scatter of the next).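

Going from methoxy to hydroxy on the 3-methoxy-5-methylphenyl group gives a number 5 percentage points lower from compound 2 to compound 3 (within the scatter) in this assay, so this change on the oxygen is not resolved at the one concentration tested. Dimethylamino in place of phenoxy on an aromatic carbon gives a number 4 percentage points higher from compound 1 to compound 3 (within the scatter) with the hydroxy group held constant, so that change is not resolved either. No evidence is available to explain these results. Still open, from the compounds shown here alone, is whether an ethyl group or a longer chain on this oxygen, or an amine in place of the hydroxy group, would give a number beyond the scatter.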